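This account rests on a few compounds, and the source may have more. Where it says the series, first, only, none or still open, it means among the compounds named here.

In a functional assay on MOLT-4 cells (Homo sapiens) for inhibition, read by MTT assay, with a stated time of 72 h (a lower number here means a stronger inhibitor, a higher number a weaker inhibitor), compound 1 `COc1cc(NC(C)CCCNC(=O)Nc2ccc(Br)cc2)c2ncccc2c1` gives 25000 nM and compound 3 `COc1cc(NC(C)CCCNC(=O)Nc2cccc(O)c2)c2ncccc2c1` gives 24000 nM. Compound 2 `COc1cc(NC(C)CCCNC(=O)NNC(=O)Nc2ccc(F)cc2)c2ncccc2c1` is reported only as a limit, >= 250000 nM. Compound 4 `COc1cc(NC(C)CCCNC(=O)NNC(=O)Nc2cccc(C(F)(F)F)c2)c2ncccc2c1` differs from compound 2 in a single group: 3-(trifluoromethyl)phenyl in place of 4-fluorophenyl on an amide-type nitrogen. The change is 3-(trifluoromethyl)phenyl in place of 4-fluorophenyl on an amide-type nitrogen, and the ((aryl)carbamoyl)amino arrangement of compound 2 stays.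

Among the measured compounds shown here, three measured steps bear on this change. The measurements show an at least 10-fold higher number from compound 1 to compound 2 (1.00 log units; beyond the scatter) and an at least 10-fold lower number from compound 2 to compound 3 (1.01 log units; beyond the scatter), both beyond the scatter, and each of these separates compound 2 from a compound without that arrangement. The nearest parallel to exchanging one aryl group for another is a 1.0-fold lower number from compound 1 to compound 3 (0.02 log units; within the scatter), which lies within the scatter, although that pair has the shorter arrangement. Compound 2 has no number, so the step from it can only be judged loosely. Given a 1.0-fold lower number from compound 1 to compound 3 (0.02 log units; within the scatter), the aryl exchange alone is expected to do little, and compound 4 is expected to remain weak, perhaps measurable where compound 2 was not. The expected change is an at least 3.5-fold lower number from compound 2 to compound 4 (0.55 log units; beyond the scatter). For compound 4 the estimated value is 70000 nM, with an expected range of 20000 nM to 250000 nM.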

Compound 4, half-maximal inhibitory concentration: 36000 nM
Compound 4: middle estimate off by 1.9-fold (0.29 log units), on the high side; the range from low to high includes it.
By their numbers in this assay, from the lowest: compounds 3, 1 and 4 (each within the scatter of the next). At a limit, above all of these: compound 2.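

In this assay, 3-(trifluoromethyl)phenyl in place of 4-fluorophenyl on an amide-type nitrogen gives an at least 6.9-fold lower number from compound 2 to compound 4 (0.84 log units; beyond the scatter), which shows that the aryl group at this place can shift the read-out while the ((aryl)carbamoyl)amino arrangement stays. Among the compounds shown here, the longer arrangement therefore does not by itself put a compound at the limit, something the earlier steps could not separate, and the only earlier aryl exchange, a 1.0-fold lower number from compound 1 to compound 3 (0.02 log units; within the scatter), lay within the scatter and had the shorter arrangement. The size of the new step remains bounded on one side, since compound 2 has a limit and not a number: the limit of >= 250000 nM in this assay, at which 1 of the 4 values shown sits.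

The exchange alters both the substituent and where it sits on the phenyl ring, so the compounds shown leave open which of the two accounts for the step. They also leave open how this arrangement would respond to an unsubstituted phenyl group, or to an amine or a carboxylic acid on that ring, and whether any such group would bring the value below that of compound 4 at 36000 nM.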